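Catechol to Chlorophenol: What One Hydroxyl Is Worth

This account rests on a few compounds, and the source may have more. Where it says the series, first, only, none or still open, it means among the compounds named here.

Compound 1, `COc1cccc(/C=N/c2ccc(OCc3ccccc3)cc2)c1O`, gives in a functional assay, with a stated time of 30 min (a higher number here means a weaker inhibitor, a lower number a stronger inhibitor), a value of > 200000 nM, which is a limit of the assay rather than a number. Compound 2, `Oc1cccc(/C=N/c2ccc(OCc3ccccc3)cc2)c1O`, gives in this assay a value of 13300 nM.

Within the data shown here, compound 2 thus holds the only genuine number in this assay, and the step of an at least 15-fold lower number from compound 1 to compound 2 (1.17 log units; beyond the scatter) shows how much the free hydroxyl contributes (the limit of > 200000 nM in this assay, at which 1 of the 2 values shown sits). Compound 3, `Oc1ccc(Cl)cc1/C=N/c1ccc(OCc2ccccc2)cc1`, carries the change (5-chloro-2-hydroxyphenyl in place of 2,3-dihydroxyphenyl on a carbon with a double bond to nitrogen), which removes that second hydroxyl. The measured step bears on this directly, so a considerable rise in this assay is expected, a 7.5-fold higher number from compound 2 to compound 3 (0.88 log units; beyond the scatter). Compound 3 is estimated at 100000 nM, within 20000 nM to 300000 nM.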

Compound 3, half-maximal inhibitory concentration: > 200000 nM
Compound 3: only a limit was reported; the forecaster's own chance of this, stated with the estimate: 40%; middle value at least 2.0-fold (0.30 log units) from the limit.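

In this assay, compound 3 returns only a limit, not a number. Putting 5-chloro-2-hydroxyphenyl in place of 2,3-dihydroxyphenyl gives an at least 15-fold higher number from compound 2 to compound 3 (1.17 log units; beyond the scatter), so a second change to this ring, different from the methyl of compound 1, also leaves no measurable value. The size of this step is therefore a minimum, not a measurement: the limit of > 200000 nM in this assay, at which 2 of the 3 values shown sit.

The swap removes a hydroxyl and adds a chlorine together, and the compounds shown do not separate the two. As far as these compounds go, whether an amine in place of one hydroxyl of 2,3-dihydroxyphenyl would keep a measurable value also stays open.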